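The source may report more compounds than this note shows. Statements on the series, on what has been measured and on what is new or still open speak of the compounds shown alone.

Compound 1 `CC(C)(C)Nc1nc2cc(-c3ccc(F)cc3)oc2c(=O)[nH]1`: > 3120 nM
Compound 2 `Cc1c(-c2ccc(Cl)cc2)sc2c(=O)[nH]c(NC(C)C)nc12`: > 25000 nM

In a toxicity assay on HepG2 cells (Homo sapiens) for cytotoxicity, read by MTT assay, with a stated time of 72 h (a higher number here means that more compound is tolerated, a lower number that less compound is tolerated), compound 1 gives only a limit of the assay, > 3120 nM. In this assay compound 2 also gives only a limit, > 25000 nM. Compound 2 thus stands at the limit of > 25000 nM in this assay, at which 1 of the 2 values shown sits, and compound 1 at the limit of > 3120 nM in this assay, at which 1 of the 2 values shown sits, so neither has a measured number. Compound 3 `Cc1c(-c2ccc(F)cc2)sc2c(=O)[nH]c(NC(C)C)nc12` differs from compound 2 in one place: fluoro in place of chloro on an aromatic carbon. Within the data shown here, no measured pair shows this swap here, so no step beyond the usual scatter is expected in this assay. Compound 3 is expected at 25000 nM, between 10000 nM and 60000 nM, most likely again as a limit. The expected step is a number no higher from compound 2 to compound 3 (the limit leaves the size open).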

Compound 3, half-maximal cytotoxic concentration: 19700 nM
Estimate against measurement, compound 3: 1.3-fold (0.10 log units) above; the range from low to high includes it.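

Among these compounds, compound 3 is the first compound here with a measured number rather than a limit in this assay, at 19700 nM. Compound 2 stands only at a limit of the assay: the limit of > 25000 nM in this assay, at which 1 of the 3 values shown sits. Fluoro in place of chloro, on an aromatic carbon para to a large group, gives an at least 1.2-fold lower number from compound 2 to compound 3 (0.10 log units; that floor lies within the scatter), so the real size of the step stays open and the swap cannot be said to make the compound less tolerated.

Still open, on these data alone, is whether a methoxy group or an amine at this position would shift the number. As far as these compounds go, it is also open whether the same swap would act alike on the core of compound 1.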